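A few compounds are considered here, and "the series" means these few. Any claim that something is new, unique, unknown or untested is made for them only; others in the source may bear on it.

Compound 1, `CCCCCCCN1CCC(C(=O)Nc2cc(Cl)c(N)cc2OC)CC1`, was examined in a functional assay on the whole organism for antagonist activity, with Mus musculus as the target; a higher number here means that more compound is needed for the effect, a lower number that less compound is needed. In this assay compound 1 gives > 10 mg/kg, which is a limit of the assay and not a number, as the limit of > 10 mg/kg in this assay, at which 1 of the 2 values shown sits, records. Compound 2, `COc1cc(N)c(Cl)cc1NC(=O)C1CCN(Cc2ccc([N+](=O)[O-])cc2)CC1`, gives > 4 mg/kg in this assay, again a limit rather than a number, as the limit of > 4 mg/kg in this assay, at which 1 of the 2 values shown sits, shows. For the measured compounds named here, the only measured step, a step that the two limits leave unreadable from compound 1 to compound 2, is therefore of unreadable size and concerns a different position anyway. Compound 3, `CCN1CCC(C(=O)Nc2cc(Cl)c(N)cc2OC)CC1`, differs from compound 1 in one place: hydrogen in place of pentyl on a saturated chain carbon, two bonds along the chain from an amine nitrogen in a ring. Going by the values given here, no measured step bears on this change, so neither direction nor size can be read from the data, and only the position of compound 1 at its limit gives any footing. Compound 3 is expected to give 10 mg/kg, within a range from 2 mg/kg to 30 mg/kg, most probably again reported as a limit. The step of a number no higher from compound 1 to compound 3 (the limit leaves the size open) is accordingly expected to be small.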

Compound 3, dose for half-maximal effect: > 10 mg/kg
Compound 3 ended at the assay's limit; the forecaster's own chance of this, stated with the estimate: 70%; the middle value lies on the limit itself.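

In this assay compound 1, compound 2 and compound 3 all stand at limits and not at numbers, so no step among them can be read: the limit of > 10 mg/kg in this assay, at which 2 of the 3 values shown sit.

The compounds shown leave open how far each lies past its limit, and whether changing these groups alters the dose at all.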